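Ring size at the chain end: pyrrolidine to piperidine

The source may report more compounds than this note shows. Statements on the series, on what has been measured and on what is new or still open speak of the compounds shown alone.

Compounds measured so far:
- Compound 1, `COc1cc2c(Oc3ccc(NC(=O)c4nn(-c5ccccc5)c(=O)cc4C)cc3F)ccnc2cc1OCCCN1CCCCC1`: 160 nM
- Compound 2, `COc1cc2c(Oc3ccc(NC(=O)c4nn(-c5ccccc5C)c(=O)cc4C)cc3F)ccnc2cc1OCCCN1CCCCC1`: 2810 nM
- Compound 3, `COc1cc2c(Oc3ccc(NC(=O)c4nn(-c5ccccc5C(F)(F)F)c(=O)cc4C)cc3F)ccnc2cc1OCCCN1CCCC1`: 140 nM

The three compounds were tested in a functional assay on HT-29 cells (Homo sapiens) for inhibition, read by MTT assay, with a stated time of 72 h; a lower number here means a stronger inhibitor, a higher number a weaker inhibitor. Among the measured compounds shown here, compound 3 gives the lowest number of the three, but its gap to compound 1 lies within the scatter, so the two cannot be told apart; the only change that clearly moved the number was an 18-fold higher number from compound 1 to compound 2 (1.24 log units; beyond the scatter), which is a large step.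

Compound 4, `COc1cc2c(Oc3ccc(NC(=O)c4nn(-c5ccccc5C(F)(F)F)c(=O)cc4C)cc3F)ccnc2cc1OCCCN1CCCCC1`, differs from compound 3 in one place: piperidin-1-yl in place of pyrrolidin-1-yl on a saturated chain carbon, three bonds along the chain from an oxygen on an aromatic ring. For the measured compounds named here, none of the measured steps touches this part of the molecule. Going by the values given here, compounds 1 and 2 both already carry the piperidin-1-yl ring, and compound 3 is the only one with the pyrrolidin-1-yl ring, so no pair shows what this swap does on its own. The numbers for compound 1 and compound 3 sit close together despite differing in this ring and elsewhere, which gives no sign of a large effect.

The expected step in this assay is therefore a 1.1-fold higher number from compound 3 to compound 4 (0.03 log units; within the scatter), nothing beyond the scatter. Compound 4 is estimated at 150 nM, with a range from 60 nM to 400 nM.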

Compound 4, half-maximal inhibitory concentration: 170 nM
Estimate against measurement, compound 4: 1.1-fold (0.05 log units) below; measured number inside the range.
By their numbers in this assay, from the lowest: compounds 3, 1 and 4 (each within the scatter of the next); then compound 2.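

In this assay, the ring at the chain end can now be read on its own, with only pyrrolidin-1-yl and piperidin-1-yl differing between two compounds (a 1.2-fold higher number from compound 3 to compound 4 (0.08 log units; within the scatter)), so in this pair the swap on the saturated chain carbon leaves the number within the scatter. Compound 4 also adds trifluoromethyl to the comparison at the aromatic carbon that already held hydrogen and methyl: the step from methyl is large (a 17-fold lower number from compound 2 to compound 4 (1.22 log units; beyond the scatter)), while the step from hydrogen stays within the scatter (a 1.1-fold higher number from compound 1 to compound 4 (0.03 log units; within the scatter)), so among these three groups, only methyl comes with a large rise (an 18-fold higher number from compound 1 to compound 2 (1.24 log units; beyond the scatter)). Nothing measured here explains why methyl stands apart from the other two groups.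

As far as these compounds go, how a morpholine ring or a dimethylamino group at the chain end would read remains open, as does the effect of a longer chain. Also open, from the compounds shown here alone, is whether chlorine or methoxy on that same aromatic carbon would track methyl or trifluoromethyl, and whether the ring swap would read the same in a compound carrying methyl there.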